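The compounds below may be only part of what the source reports. "The series", "measured", "known", "first", "only" and "open" are said of these compounds alone.

Working notes on the series. Compound 3 `COC(=O)Cn1cc(Nc2ncnc3ccc(-c4cnc(OC)c(NS(=O)(=O)c5ccc(F)cc5F)c4)cc23)cn1` stands lowest in a functional assay on MCF7 cells (Homo sapiens) for antiproliferative activity, read by sulforhodamine B assay, with a stated time of 72 h (on this read-out lower numbers stand for stronger inhibition and higher numbers for weaker inhibition), at 670 nM; compound 1 `COc1ncc(-c2ccc3ncnc(Nc4ccc(OCCO)cc4)c3c2)cc1NS(=O)(=O)c1ccc(F)cc1F` gives 1650 nM, compound 2 `COc1ncc(-c2ccc3ncnc(Nc4ccc(OCCO)c(F)c4)c3c2)cc1NS(=O)(=O)c1ccc(F)cc1F` gives 4820 nM. The measured steps run a 2.5-fold lower number from compound 1 to compound 3 (0.39 log units; beyond the scatter) and a 7.2-fold lower number from compound 2 to compound 3 (0.86 log units; beyond the scatter), while the fluoro on the aromatic carbon gives a 2.9-fold higher number from compound 1 to compound 2 (0.47 log units; beyond the scatter). Compound 4 `COc1ncc(-c2ccc3ncnc(Nc4ccc(OCCO)nc4)c3c2)cc1NS(=O)(=O)c1ccc(F)cc1F` differs from compound 3 by 6-(2-hydroxyethoxy)pyridin-3-yl in place of 1-((methoxycarbonyl)methyl)-1H-pyrazol-4-yl on a nitrogen on an aromatic ring, which returns to a 2-hydroxyethoxy-bearing six-membered ring as in compound 1. The step from compound 1 to compound 3 is the relevant comparison, so compound 4 is expected to move back toward compound 1, an estimated 2.2-fold higher number from compound 3 to compound 4 (0.35 log units; beyond the scatter) in this assay. Compound 4 is thus estimated at 1500 nM, with a range of 500 nM to 4500 nM.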

Compound 4, half-maximal inhibitory concentration: 4300 nM
The estimate for compound 4 lay 2.9-fold (0.46 log units) below the measured number; low and high end bracket the measured number.
By their numbers in this assay, from the lowest: compound 3; then compound 1; then compounds 4 and 2 (each within the scatter of the next).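

In this assay, keeping the 2-hydroxyethoxy chain does not by itself hold the level of compound 1: 6-(2-hydroxyethoxy)pyridin-3-yl in place of 4-(2-hydroxyethoxy)phenyl gives a 2.6-fold higher number from compound 1 to compound 4 (0.42 log units; beyond the scatter). The 1-((methoxycarbonyl)methyl)-1H-pyrazol-4-yl group keeps its lead over this ring, with a 6.4-fold higher number from compound 3 to compound 4 (0.81 log units; beyond the scatter), while a 1.1-fold lower number from compound 2 to compound 4 (0.05 log units; within the scatter) sets no order between the pyridine and the 3-fluoro-4-(2-hydroxyethoxy)phenyl group. No available evidence accounts for these steps. Open, from the compounds shown here alone, is whether the lead of compound 3 belongs to the pyrazole ring or to its (methoxycarbonyl)methyl group. A pyrazole carrying a carboxylic acid or a 2-hydroxyethyl chain instead would separate the two.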